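This account rests on a few compounds, and the source may have more. Where it says the series, first, only, none or still open, it means among the compounds named here.

Measured in a functional assay on LoVo cells (Homo sapiens) for inhibition, read by MTT assay, with a stated time of 48 h; on this read-out lower numbers stand for stronger inhibition and higher numbers for weaker inhibition:
- compound 1 `COc1ccc(N(C)c2nc(C)nc3ccccc23)cc1C(=O)OCC[Se]C#N` gives 2960 nM
- compound 2 `COc1ccc(N(C)c2nc(C)nc3ccccc23)cc1[Se]C#N` gives 73 nM

Not yet measured: compound 3 `COc1ccc(N(C)c2nc(C)nc3ccccc23)cc1C(=O)OCCCCC[Se]C#N`.

Compound 1 holds the higher of the two numbers, so it is the weaker of the pair. Compound 3 differs from compound 1 as follows: a group of 6 heavy atoms (4 carbon, 1 nitrogen, 1 selenium; no ring) in place of a group of 3 heavy atoms (1 carbon, 1 nitrogen, 1 selenium; no ring), on a saturated chain carbon, two bonds along the chain from an oxygen next to a carbonyl group. Among the measured compounds shown here, the only measured step is a 41-fold lower number from compound 1 to compound 2 (1.61 log units; beyond the scatter), which is large and beyond the scatter. That step replaces the whole group on the aromatic carbon, whereas compound 3 keeps that group and changes only the far end of its chain. For the measured compounds named here, it therefore bears only weakly on this change, and no measured step covers it directly. In this assay no shift beyond the scatter is expected, and any direction is uncertain. The expected step is a 1.2-fold lower number from compound 1 to compound 3 (0.07 log units; within the scatter). Compound 3 is estimated at 2500 nM, with an expected range from 800 nM to 7000 nM.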

Compound 3, half-maximal inhibitory concentration: 714 nM
The estimate for compound 3 lay 3.5-fold (0.54 log units) above the measured number; the whole stated range lies above it.
By their numbers in this assay, from the lowest: compound 2; then compound 3; then compound 1.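

In this assay, this saturated chain carbon is a position that responds: a 4.1-fold lower number from compound 1 to compound 3 (0.62 log units; beyond the scatter), a modest step beyond the scatter, while the carbonyl link to the aromatic carbon and the shared core stay unchanged. The earlier step replaced the whole group on the aromatic carbon, so it could not show that a change confined to the chain, with the selenium and nitrile retained at its end, is enough to move the number. Nothing available explains this shift, and no measurement beyond these numbers bears on it.

Among the compounds shown here, with only two chain lengths in this comparison, no trend with length can be claimed, and a still longer chain could lower the number further, leave it unchanged or raise it. The compounds shown also leave open how an amide in place of the ester, or sulfur in place of selenium, would behave on this chain.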